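Swapping a trifluorophenyl end for a methylthiazole

A few compounds are considered here, and "the series" means these few. Any claim that something is new, unique, unknown or untested is made for them only; others in the source may bear on it.

Measured in a toxicity assay on MT2 cells (Homo sapiens) for cytotoxicity, read by XTT assay, with a stated time of 4 days; on this read-out lower numbers stand for higher toxicity in this test and higher numbers for lower toxicity in this test:
- compound 1 `Cc1nc(C)c([C@H](OC(C)(C)C)C(=O)O)c(N2CCC(C)(C)CC2)c1-c1ccc(OCCc2ccc(F)cc2F)cc1`: >= 33500 nM, a limit
- compound 2 `Cc1nc(C)c([C@H](OC(C)(C)C)C(=O)O)c(N2CCC(C)(C)CC2)c1-c1ccc(OCCc2cc(F)c(F)cc2F)cc1`: >= 33500 nM, a limit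
- compound 3 `Cc1nc(C)c([C@H](OC(C)(C)C)C(=O)O)c(N2CCC(C)(C)CC2)c1-c1ccc(OC2COCC2c2ccc(F)cc2)cc1`: >= 32000 nM; >= 32000 nM (2 entries), a limit

Compound 2 has no exact number and stands only at the limit of >= 33500 nM in this assay, at which 2 of the 3 values shown sit. The next compound, compound 4 `Cc1nc(CCOc2ccc(-c3c(C)nc(C)c([C@H](OC(C)(C)C)C(=O)O)c3N3CCC(C)(C)CC3)cc2)cs1`, keeps the shared core and the ether chain of compound 2. Its change is 2-methyl-1,3-thiazol-4-yl in place of 2,4,5-trifluorophenyl on a saturated chain carbon, two bonds along the chain from an oxygen on an aromatic ring. In short, 2-methyl-1,3-thiazol-4-yl replaces 2,4,5-trifluorophenyl on a saturated chain carbon.

Among the compounds with values here, only one measured step bears on this end of the molecule, and it is a step that the two limits leave unreadable from compound 1 to compound 2. Within the data shown here, that step gives no size to carry over, and no measured step covers a change of this kind. The expected result is therefore no shift beyond the scatter, and the estimated step is a number no higher from compound 2 to compound 4 (the limit leaves the size open). A reading in this assay that returns only a limit again is also likely. For compound 4 the estimate is 33500 nM, with an expected range from 15000 nM to 60000 nM.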

Compound 4, half-maximal cytotoxic concentration: >= 25000 nM
Compound 4: only a limit was reported; the forecaster's own chance of this, stated with the estimate: 80%; the middle value lies beyond the limit too.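

In this assay compound 4 gives >= 25000 nM, which is a limit. Within the data shown here, compound 1 and compound 2 also stand only at limits, and no step to compound 4 can be read from either. The compounds shown leave open where the half-maximal cytotoxic concentration of any of them lies, and whether 2-methyl-1,3-thiazol-4-yl in place of 2,4,5-trifluorophenyl shifts it at all.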